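A thiadiazolylsulfanyl in place of the piperazine

This account rests on a few compounds, and the source may have more. Where it says the series, first, only, none or still open, it means among the compounds named here.

Compound 1 `CCN1CCN(c2cc(C(F)(F)F)nc(SCc3ccc(C(F)(F)F)cc3)n2)CC1` gives 27200 nM in a functional assay on PC-3 cells (Homo sapiens) for inhibition, read by MTT assay, with a stated time of 72 h; on this read-out lower numbers stand for stronger inhibition and higher numbers for weaker inhibition.
Compound 2 `FC(F)(F)c1ccc(CSc2nc(N3CCN(c4ccccn4)CC3)cc(C(F)(F)F)n2)cc1` gives > 50000 nM in this assay, a limit of the assay.
Compound 3 `FC(F)(F)c1ccc(CSc2nc(N3CCN(c4ncccn4)CC3)cc(C(F)(F)F)n2)cc1` gives > 50000 nM in this assay, a limit of the assay.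

Going by the values given here, compound 1 holds the only number in this set. The other two values are the limit of > 50000 nM in this assay, at which 2 of the 3 values shown sit. Compound 4 `FC(F)(F)c1ccc(CSc2nc(Sc3nncs3)cc(C(F)(F)F)n2)cc1` is not yet measured. It differs from compound 1 by (1,3,4-thiadiazol-2-yl)sulfanyl in place of 4-ethylpiperazin-1-yl on an aromatic carbon. The measured steps touch another part of the core: an at least 1.8-fold higher number from compound 1 to compound 2 (0.26 log units; that floor lies within the scatter) and an at least 1.8-fold higher number from compound 1 to compound 3 (0.26 log units; that floor lies within the scatter) each ran to a limit of the assay, and neither alters the group replaced in compound 4. Among the compounds with values here, no measured step therefore bears directly on this change, and the expectation rests on compound 1 alone, with wide uncertainty. Compound 4 is expected to give about 30000 nM, within 8000 nM to 110000 nM. That estimate means a 1.1-fold higher number from compound 1 to compound 4 (0.04 log units; within the scatter).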

Compound 4, half-maximal inhibitory concentration: 7880 nM
For compound 4 the middle estimate is 3.8-fold (0.58 log units) above the measured one; measured number outside the range, below it.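

In this assay, exchanging the whole 4-ethylpiperazin-1-yl group at this position, rather than altering the group on its ring nitrogen, gives a 3.5-fold lower number from compound 1 to compound 4 (0.54 log units; beyond the scatter). The position therefore does not depend on the piperazine, and (1,3,4-thiadiazol-2-yl)sulfanyl can stand in its place. This is the only change shown that lowers the number beyond the scatter, while the other changes ended at a limit: the limit of > 50000 nM in this assay, at which 2 of the 4 values shown sit.

The compounds shown leave open whether the sulfanyl link or the thiadiazole ring carries this step. Going by these compounds, it also remains open whether a phenylsulfanyl group, a morpholine or a simple amine at this position would give a similar number.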